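The source may hold more compounds than are shown below. What is called first, only, known or untested is meant among the compounds shown, and "the series" means these compounds.

The measured compounds:
- compound 1, `COc1cccc(/C=C2\SC(=O)N(Cc3ccc(C(=O)O)cc3)C2=O)c1`, gives 55000 nM in a functional assay on A549 cells (Homo sapiens) for cytotoxicity, read by MTT assay, with a stated time of 24 h; a lower number here means a stronger inhibitor, a higher number a weaker inhibitor
- compound 2, `O=C(O)c1ccc(CN2C(=O)S/C(=C\c3cccnc3)C2=O)cc1`, gives 75000 nM in this assay
- compound 3, `O=C(O)c1ccc(CN2C(=O)S/C(=C\c3ccccn3)C2=O)cc1`, gives 80000 nM in this assay

All three share one core and differ only in the aromatic group hanging from the double-bonded chain carbon. Compound 3 has the highest of the three numbers, yet its steps to the others, a 1.5-fold higher number from compound 1 to compound 3 (0.16 log units; within the scatter) and a 1.1-fold higher number from compound 2 to compound 3 (0.03 log units; within the scatter), are within the scatter, so the three compounds cannot be told apart on these data.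

Compound 4, `O=C(O)c1ccc(CN2C(=O)S/C(=C\c3cccs3)C2=O)cc1`, has not yet been measured in this assay. It differs from compound 3 in one place: thiophen-2-yl in place of pyridin-2-yl on a double-bonded chain carbon bound to a double-bonded ring carbon. For the measured compounds named here, the steps that bear on this are the aryl swaps at the same place already seen, a 1.4-fold higher number from compound 1 to compound 2 (0.13 log units; within the scatter), a 1.5-fold higher number from compound 1 to compound 3 (0.16 log units; within the scatter) and a 1.1-fold higher number from compound 2 to compound 3 (0.03 log units; within the scatter), none of which moved the number beyond the scatter. Exchanging one small aromatic group for another at this position has so far left the read-out unchanged, so for compound 4 no step beyond the scatter in either direction is expected, a 1.1-fold lower number from compound 3 to compound 4 (0.03 log units; within the scatter).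

Compound 4 is therefore estimated at 75000 nM in this assay, with a likely range from 40000 nM to 150000 nM.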

Compound 4, half-maximal inhibitory concentration: 80000 nM
For compound 4 the middle estimate is 1.1-fold (0.03 log units) below the measured one; low and high end bracket the measured number.
By their numbers in this assay, from the lowest: compounds 1, 2, 3 and 4 (each within the scatter of the next).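

The earlier compounds shown here carried only six-membered aromatic rings at this place, while compound 4 brings a five-membered aromatic ring with sulfur as its hetero atom. Even so, this assay shows no change at the digits printed from compound 3 to compound 4 (within the scatter), and the comparisons with the other two groups give a 1.1-fold higher number from compound 2 to compound 4 (0.03 log units; within the scatter) and a 1.5-fold higher number from compound 1 to compound 4 (0.16 log units; within the scatter), so neither this change in ring size nor this change of hetero atom separates compound 4 from the other three compounds. Nothing measured here offers a reason for this lack of separation.

The compounds shown leave open whether a group of a different kind on the double-bonded chain carbon, such as a non-aromatic cyclohexyl ring or a phenyl ring bearing an amine, would move the number beyond the scatter. They also leave open what would happen if the carboxylic acid shared by all four compounds gave way to a methyl ester or an amide, since every change seen so far lies at the one place.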